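Swapping Ethoxy for Hydroxy in Compound 2

The compounds below may be only part of what the source reports. "The series", "measured", "known", "first", "only" and "open" are said of these compounds alone.

Of the compounds shown here, two have been measured in a functional assay on MCF7 cells (Homo sapiens) for cytotoxicity, read by MTT assay, with a stated time of 24 h; a higher number here means a weaker inhibitor, a lower number a stronger inhibitor.

- Compound 1 `CCOC1C=C(CC[C@]2(C)[C@@H](C)CC[C@@]3(C)C(C(=O)O)=CC=C[C@@H]23)C(=O)O1` gives > 40000 nM, a limit.
- Compound 2 `C=C1CC[C@H](C)[C@@](C)(CCC2=CC(OCC)OC2=O)C/C=C\C=C/1C(=O)O` gives > 40000 nM, a limit.

Neither entry is a true number, so compound 2 has no exact position, only the limit shared by both compounds: the limit of > 40000 nM in this assay, at which 2 of the 2 values shown sit. Compound 3 `C=C1CC[C@H](C)[C@@](C)(CCC2=CC(O)OC2=O)C/C=C\C=C/1C(=O)O` differs from compound 2 in one place: hydrogen in place of ethyl on an oxygen on a saturated carbon. Here hydrogen takes the place of ethyl on an oxygen on a saturated carbon, turning ethoxy to hydroxy. Within the data shown here, no measured pair shows this change, so little guides the forecast. In this assay, no step beyond the scatter is expected, and any visible step would be towards a stronger inhibitor. For compound 3 the estimated value is 40000 nM, with an expected range of 15000 nM to 80000 nM. The expected change is a number no higher from compound 2 to compound 3 (the limit leaves the size open).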

Compound 3, half-maximal inhibitory concentration: > 40000 nM
Compound 3: no number, only a limit; the forecaster's own chance of this, stated with the estimate: 75%; the middle value sits exactly at the limit.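

Compound 2 and compound 3 both end at a limit rather than a true number, so no step can be read between them: the limit of > 40000 nM in this assay, at which 3 of the 3 values shown sit. As far as these compounds go, how strong each compound really is, and whether replacing ethoxy with hydroxy changes that, stays open.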